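The compounds below may be only part of what the source reports. "The series", "measured", "known", "first", "only" and "open" are said of these compounds alone.

These compounds were tested in an assay on HEK293-A cells with putative P2Y purinoceptor 10 (Mus musculus) as the target, with a stated time of 1.5 h; a lower number here means a smaller maximal response, a higher number a larger maximal response. Within the data shown here, compound 1, with the structure `CCCCCCCCCCCOc1ccccc1CCC(=O)OCc1ccccc1OP(=O)(O)OC[C@H](N)C(=O)O`, gives the only number so far: in this assay compound 1 reaches 0.02, a response barely above nothing. Compound 2, with the structure `CCCCCCCC/C=C\CCCCCCCC(=O)O[C@@H]1C=CCO[C@@H]1COP(=O)(O)OC[C@H](N)C(=O)O`, is reported differently: in this assay compound 2 is recorded as "not active" (no number reported), so no single number describes it. The same is true of compound 3, with the structure `N[C@@H](COP(=O)(O)OC[C@H]1OCCC[C@@H]1OC(=O)CCc1ccccc1OCc1cccc(Oc2ccccc2)c1)C(=O)O`; in this assay compound 3 is likewise recorded as "not active" (no number reported). Compound 2 therefore stands among the two compounds for which the assay returned no number at all, while the one numbered result, that of compound 1, sits very low.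

Compound 4, with the structure `CCCCCCCC/C=C\CCCCCCCC(=O)O[C@H]1C=CCO[C@@H]1COP(=O)(O)OC[C@H](N)C(=O)O`, is the compound not yet measured. It is built from the same atoms and bonds as compound 2, and the whole difference is this: the two compounds have the same atoms and bonds; at least one stereo element is drawn with a configuration in one of them and without one in the other: 1 of 5 stereo elements differ; a stereocentre at a saturated ring carbon is drawn R in compound 2 and S in compound 4.

Among the measured compounds shown here, no measured pair separated by such a change exists here, so nothing shows how far flipping one stereocentre can move a response. For the measured compounds named here, since compound 2 gave no measurable response and the only number seen so far is tiny, the expectation for compound 4 is a response that stays within scatter of nothing. The estimate for compound 4 is 0.03, with a range from 0 to 0.12.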

Compound 4, intrinsic activity: the largest response reached, as a fraction of the reference agonist's: "not active" (no number reported)
No number was reported for compound 4, and the estimate cannot be compared.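

In this assay compound 2 and compound 4 are both recorded without a number, so no step can be read between them. The compounds shown leave open whether the stereocentre at the saturated ring carbon, drawn R in compound 2 and S in compound 4, can change the maximal response at all: the fact that one of compounds 2 and 4 is drawn with a defined configuration and the other without, at the place where they differ.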